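Swapping methyl for bromo on the aryl ring

A few compounds are considered here, and "the series" means these few. Any claim that something is new, unique, unknown or untested is made for them only; others in the source may bear on it.

Three compounds have been measured in a functional assay on B16-F10 cells (Mus musculus) for inhibition, read by MTT assay, with a stated time of 72 h; on this read-out lower numbers stand for stronger inhibition and higher numbers for weaker inhibition:
Compound 1, `CC(C)c1ccc(-c2nc(SCc3cn(CC(=O)NC(=O)Nc4ccccn4)nn3)nc(Nc3cccc(C(F)(F)F)c3)c2C#N)cc1`, gives 1700 nM.
Compound 2, `COc1ccccc1Nc1nc(SCc2cn(CC(=O)NC(=O)Nc3ccccn3)nn2)nc(-c2ccc(C)cc2)c1C#N`, gives 8580 nM.
Compound 3, `Cc1ccc(-c2nc(SCc3cn(CC(=O)NC(=O)Nc4ccccn4)nn3)nc(Nc3cccc(C(F)(F)F)c3)c2C#N)cc1`, gives 9580 nM.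

Compound 3 has the highest number of the three. Compound 2 sits so close that the two cannot be told apart, since a 1.1-fold higher number from compound 2 to compound 3 (0.05 log units; within the scatter). Compound 1 is clearly separated: a 5.6-fold higher number from compound 1 to compound 3 (0.75 log units; beyond the scatter).

Compound 4, `N#Cc1c(Nc2cccc(C(F)(F)F)c2)nc(SCc2cn(CC(=O)NC(=O)Nc3ccccn3)nn2)nc1-c1ccc(Br)cc1`, is obtained from compound 3 by one change, (bromo in place of methyl on an aromatic carbon). The step from compound 1 to compound 3 touches the same aromatic carbon, with isopropyl giving way to methyl, and it moved the number by a modest, real amount. The step from compound 2 to compound 3 changes a different part and stays within scatter. Within the data shown here, no measured pair puts bromo against methyl here, so the direction of this change is not fixed by the data; the one step at this carbon suggests that a change there can matter, but it gives no sign for bromo specifically.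

Compound 4 is therefore expected to lie near compound 3, with the step of a 1.4-fold lower number from compound 3 to compound 4 (0.14 log units; within the scatter) considered likely to stay within or just beyond the scatter. The estimate for compound 4 in this assay is 7000 nM, with a range from 2500 nM to 20000 nM.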

Compound 4, half-maximal inhibitory concentration: 4550 nM
For compound 4 the middle estimate is 1.5-fold (0.19 log units) above the measured one, and the stated range covers the measured number.
By their numbers in this assay, from the lowest: compound 1; then compounds 4, 2 and 3 (each within the scatter of the next, the first and the last beyond it).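

Among these compounds, this is the first direct comparison of bromo with methyl at this aromatic carbon. In this assay, changing 4-methylphenyl to 4-bromophenyl gives a 2.1-fold lower number from compound 3 to compound 4 (0.32 log units; beyond the scatter), so the change has a direction here, though the step is modest and only just clears the usual scatter. Bromo does not match isopropyl at the same carbon, with a 2.7-fold higher number from compound 1 to compound 4 (0.43 log units; beyond the scatter), and methyl lies further from isopropyl, with a 5.6-fold higher number from compound 1 to compound 3 (0.75 log units; beyond the scatter). Among compound 1, compound 4 and compound 3, which differ only at this carbon, the numbers therefore rise from isopropyl through bromo to methyl, with every step beyond the scatter and no compound here going against that order. Nothing available explains why the number shifts with the group at this carbon.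

Among the compounds shown here, this order rests on three groups, all with 3-(trifluoromethyl)phenyl on the nitrogen; compound 2, the only compound with 2-methoxyphenyl there, carries methyl, so it remains open whether bromo or isopropyl would have the same effect alongside 2-methoxyphenyl. Going by these compounds, it also remains open where a chloro, a tert-butyl, an amine or a carboxylic acid at this carbon would fall.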